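The source may hold more compounds than are shown below. What is called first, only, known or untested is meant among the compounds shown, and "the series" means these compounds.

Measured so far:
compound 1 `S=c1oc(-c2ccc3c(c2)OCCO3)nn1CNc1ccccc1` — 5140 nM
compound 2 `CCCCCCCCCCCCCCCCNCn1nc(-c2ccc3c(c2)OCCO3)oc1=S` — 22900 nM
compound 3 `Fc1cccc(F)c1NCn1nc(-c2ccc3c(c2)OCCO3)oc1=S` — 3320 nM

In a functional assay, with a stated time of 6 min (a lower number here means a stronger inhibitor, a higher number a weaker inhibitor), compound 3 has the lowest of the three numbers. Compound 1 sits close by, since the step of a 1.5-fold lower number from compound 1 to compound 3 (0.19 log units; within the scatter) stays within the scatter, while compound 2 lies further off, beyond the scatter. Compound 4 `S=c1oc(-c2ccc3c(c2)OCCO3)nn1CNc1cccc(Br)c1` differs from compound 3 in one place: 3-bromophenyl in place of 2,6-difluorophenyl on an amine nitrogen. For the measured compounds named here, the one measured step that bears on this position, a 1.5-fold lower number from compound 1 to compound 3 (0.19 log units; within the scatter), was small; no measured step covers a bromine on that ring. A change of similar size is therefore expected, a 1.2-fold higher number from compound 3 to compound 4 (0.08 log units; within the scatter), with no clear direction. Compound 4 is estimated at 4000 nM, within a range of 1500 nM to 11000 nM.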

Compound 4, half-maximal inhibitory concentration: 10800 nM
Estimate against measurement, compound 4: 2.7-fold (0.43 log units) below, and the stated range covers the measured number.
By their numbers in this assay, from the lowest: compounds 3 and 1 (each within the scatter of the next); then compound 4; then compound 2.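

Bromo in place of hydrogen on the aromatic carbon gives a 2.1-fold higher number from compound 1 to compound 4 (0.32 log units; beyond the scatter) in this assay, so this ring, unlike in the earlier small step, does respond beyond the scatter to a single added atom. 3-bromophenyl in place of 2,6-difluorophenyl gives a 3.3-fold higher number from compound 3 to compound 4 (0.51 log units; beyond the scatter) as well, which shows that these two halogen-bearing rings are not interchangeable here. Nothing available explains this shift.

Still open, going by these compounds, is whether chloro, methyl or methoxy on the same ring would give a similar rise. Whether bromine or its place on the ring drives the change also remains unsettled.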